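Tolerated concentration in the series: small ring for aryl

A few compounds are considered here, and "the series" means these few. Any claim that something is new, unique, unknown or untested is made for them only; others in the source may bear on it.

Measured so far:
compound 1, `CCCc1ccc(C#CC#Cc2cn([C@H]3C[C@H](O)[C@@H](CO)O3)c(=O)[nH]c2=O)cc1`: 100000 nM
compound 2, `Cc1cc(C#CC#Cc2cn([C@H]3C[C@H](O)[C@@H](CO)O3)c(=O)[nH]c2=O)ccc1F`: 100000 nM
compound 3, `O=c1[nH]c(=O)n([C@H]2C[C@H](O)[C@@H](CO)O2)cc1C#CC#CCC1CCCC1`: a limit, > 100000 nM

In an ADME assay on HEL cells (Homo sapiens) for cytotoxicity, read by microscopy (a higher number here means that more compound is tolerated, a lower number that less compound is tolerated), compound 1 gives 100000 nM, level with compound 2 at the digits shown. Compound 3 reaches only a limit of the assay, > 100000 nM. Compound 4, `O=c1[nH]c(=O)n([C@H]2C[C@H](O)[C@@H](CO)O2)cc1C#CC#CC1CC1`, is not yet measured; its change from compound 1 is cyclopropyl in place of 4-propylphenyl on a triple-bonded carbon. The step of no change at the digits printed from compound 1 to compound 2 (within the scatter) left the number unchanged, and the step of a number no lower from compound 1 to compound 3 (the limit leaves the size open) gave a number no lower with a saturated ring in place of 4-propylphenyl. Both bear on the present change. For the measured compounds named here, no measured step lowered the tolerated concentration, so no fall beyond the scatter is expected; the size of any rise stays open because of the limit (the limit of > 100000 nM in this assay, at which 1 of the 3 values shown sits). Compound 4 is therefore expected at 100000 nM, between 50000 nM and 200000 nM, a step of no change at the digits printed from compound 1 to compound 4 (within the scatter).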

Compound 4, minimum cytotoxic concentration: > 100000 nM
Compound 4: only a limit was reported (the forecaster's own chance of this, stated with the estimate: 50%); the middle value lies on the limit itself.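

In this assay, cyclopropyl on the triple-bonded carbon gives a number no lower from compound 1 to compound 4 (the limit leaves the size open), and likewise a number no lower from compound 2 to compound 4 (the limit leaves the size open). As with cyclopentylmethyl in compound 3, a saturated ring brings no fall in the tolerated concentration, and this now holds for a group of 3 heavy atoms in place of the 9 of 4-propylphenyl. The sizes of these steps stay open, and the step between compound 3 and compound 4 cannot be read, because of a limit: the limit of > 100000 nM in this assay, at which 2 of the 4 values shown sit.

From the compounds shown here alone, whether an amine or a carboxylic acid on the triple-bonded carbon would lower the tolerated concentration stays open. Going by these compounds, how far compound 3 and compound 4 lie apart also stays open.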